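Carbamate variation on the shared core: buffer stability notes

The compounds below may be only part of what the source reports. "The series", "measured", "known", "first", "only" and "open" are said of these compounds alone.

Measured compounds:
- Compound 1 `CC(C)C(=O)OCOC(=O)N1CCN(C(=O)c2nc(Nc3cc(C4CC4)[nH]n3)c3cc(Cl)ccc3n2)C[C@H]1C` in a physicochemical assay, read by HPLC, in phosphate buffer, with a stated time of 2 h, at pH 7.4 (a lower number here means that less of the compound is left, a higher number that more of the compound is left), gives 93.5%.
- Compound 2 `C[C@@H]1CN(C(=O)c2nc(Nc3cc(C4CC4)[nH]n3)c3cc(Cl)ccc3n2)CCN1C(=O)OC(C)(C)C` in this assay gives 99.1%.
- Compound 3 `CC(OC(=O)N1CCN(C(=O)c2nc(Nc3cc(C4CC4)[nH]n3)c3cc(Cl)ccc3n2)C[C@H]1C)OC(=O)C(C)(C)C` in this assay gives 90.5%.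

Compound 1 stands second highest of the three numbers in this assay; its nearest neighbour is compound 3, its furthest compound 2, and both gaps lie within the scatter. Compound 4 `COC(=O)N1CCN(C(=O)c2nc(Nc3cc(C4CC4)[nH]n3)c3cc(Cl)ccc3n2)C[C@H]1C` is not yet measured in this assay. It differs from compound 1 by hydrogen in place of (isopropylcarbonyl)oxy on a saturated chain carbon bound to an oxygen next to a carbonyl group, the remaining carbamate being a methoxycarbonyl.

Among the compounds with values here, the steps that bear on this change are all at the same oxygen next to a carbonyl group: a number 5.6 percentage points higher from compound 1 to compound 2 (within the scatter), a number 3 percentage points lower from compound 1 to compound 3 (within the scatter) and a number 8.6 percentage points lower from compound 2 to compound 3 (within the scatter). None of them left the scatter, so the three carbamates shown behave alike in this assay. The change to compound 4 is another variation at that oxygen, and no step beyond the scatter in this assay is expected from it; the expected step is a number 2.5 percentage points higher from compound 1 to compound 4 (within the scatter). Compound 4 is therefore estimated at 96% in this assay, with a range from 88% to 100%.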

Compound 4, percent of the compound remaining: 100%
Compound 4: the middle estimate sits 4 percentage points below what was measured; the measured number falls inside the stated range.
By their numbers in this assay, from the lowest: compounds 3, 1, 2 and 4 (each within the scatter of the next).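

Taking (isopropylcarbonyl)oxy off the saturated chain carbon bound to an oxygen next to a carbonyl group, which leaves a methoxycarbonyl, gives a number 6.5 percentage points higher from compound 1 to compound 4 (within the scatter) in this assay. The methoxycarbonyl also stays level with the other two carbamates, with a number 9.5 percentage points higher from compound 3 to compound 4 (within the scatter) and a number 0.9 percentage points higher from compound 2 to compound 4 (within the scatter), so the series now spans a methyl, a tert-butyl and two chains carrying an ester without any step at this oxygen leaving the scatter. No measurement available here accounts for this sameness.

Still open, on these data alone, is whether an amine or a carboxylic acid on the chain at this oxygen, or a longer chain, would leave the scatter in this assay. The same question stands for a urea in place of the carbamate.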